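The source may report more compounds than this note shows. Statements on the series, on what has been measured and on what is new or still open speak of the compounds shown alone.

Measured compounds and their values in the assay of largest response:

Compound 1, `CCC(=O)NCc1cc(OC)ccc1F`: 69%
Compound 2, `CCCC(=O)NCc1cc(OC)ccc1F`: 43%
Compound 3, `COc1ccc(CNC(C)=O)cc1F`: 77%

In an assay on isolated protein for agonist activity at melatonin receptor type 1C (Xenopus laevis), read by spectrophotometry (a higher number here means a larger maximal response, a lower number a smaller maximal response), compound 3 holds the highest of the three numbers. Its nearest neighbour is compound 1, and the gap between the two is within the usual scatter, so neither can be ranked above the other. Compound 2 lies furthest away, and that gap is beyond the scatter.

The next compound, compound 4, `CCCC(=O)NCc1ccc(OC)c(F)c1`, comes from compound 3 by a single change: ethyl in place of hydrogen on a saturated chain carbon bound to a carbonyl carbon. Among the compounds with values here, the one measured step that speaks to this is a number 26 percentage points lower from compound 1 to compound 2 (beyond the scatter), where the chain next to the carbonyl grew by one carbon on a core that differs from that of compound 3 only in where the groups sit. Here the chain grows by two carbons at once, so a drop in this assay is expected, plausibly of at least the same size. Compound 4 is expected to give about 47%, with a range from 30% to 65%. For compound 4 this amounts to an expected a number 30 percentage points lower from compound 3 to compound 4 (beyond the scatter), due to a number 26 percentage points lower from compound 1 to compound 2 (beyond the scatter) pointing downward with longer chains.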

Compound 4, largest response reached (reported as efficacy), in percent of the reference or control that the assay uses: 57%
Beside the measured number, compound 4's estimate is 10 percentage points below it; low and high end bracket the measured number.
By their numbers in this assay, from the lowest: compound 2; then compound 4; then compounds 1 and 3 (each within the scatter of the next).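

Going from acetyl to propylcarbonyl gives a number 20 percentage points lower from compound 3 to compound 4 (beyond the scatter) in this assay, so adding ethyl on the saturated chain carbon bound to the carbonyl carbon also lowers the maximal response on the core of compound 3. Together with a number 26 percentage points lower from compound 1 to compound 2 (beyond the scatter) on its own core, this means that both measured chain extensions at this place point downward, and no pair shown goes against that direction, although the evidence rests on only these two pairs. The longer chain reduces the response without removing it, since compound 4 still reaches 57% in this assay, but nothing available here explains why the response falls with this change.

The compounds shown leave open how the response behaves with methyl in place of hydrogen on the core of compound 3, which would show whether the fall builds gradually as the chain grows. They also leave open whether a still longer chain such as propyl in place of ethyl, or a ring such as cyclopropyl, would lower the response further or bring it back up.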